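Working notes: propargyl in place of naphthalen-1-yl

The compounds below may be only part of what the source reports. "The series", "measured", "known", "first", "only" and "open" are said of these compounds alone.

Compound 3 `O=C1c2ccccc2N(Cc2cccc3ccccc23)S(=O)(=O)N1Cc1ccccc1` stands only at a limit in a functional assay on MRC5 cells (Homo sapiens); a higher number here means that more compound is tolerated, a lower number that less compound is tolerated: compound 3 gives > 58000 nM, which is a limit and not a number. Compound 1 `COc1ccc(CN2c3ccccc3C(=O)N(Cc3ccccc3)S2(=O)=O)cc1` gives 61000 nM and compound 2 `O=C1c2ccccc2N(Cc2ccccc2)S(=O)(=O)N1Cc1ccccc1` gives 66000 nM; the step of a 1.1-fold higher number from compound 1 to compound 2 (0.03 log units; within the scatter) lies within the scatter. The steps a step that the limit leaves unreadable from compound 1 to compound 3 and a step that the limit leaves unreadable from compound 2 to compound 3 cannot be sized because of the limit of > 58000 nM in this assay, at which 1 of the 3 values shown sits. Compound 4 `C#CCCN1c2ccccc2C(=O)N(Cc2ccccc2)S1(=O)=O` differs from compound 3 by propargyl in place of naphthalen-1-yl on a saturated chain carbon bound to a sulfonamide nitrogen in a ring. Within the data shown here, no measured step covers an exchange of this kind at the saturated chain carbon, and the three values that exist all sit near one level, so no step beyond the scatter is expected from compound 3 to compound 4; the estimated step is a step that the limit leaves unreadable from compound 3 to compound 4. Compound 4 is expected to give 60000 nM, between 30000 nM and 120000 nM.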

Compound 4, half-maximal cytotoxic concentration: 77000 nM
Compound 4: middle estimate off by 1.3-fold (0.11 log units), on the low side, within the range that was stated.
By their numbers in this assay, from the lowest: compounds 1, 2 and 4 (each within the scatter of the next).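

In this assay, the level seen with aromatic groups at the saturated chain carbon bound to a sulfonamide nitrogen in a ring holds with propargyl, which brings no ring: replacing phenyl gives a 1.2-fold higher number from compound 2 to compound 4 (0.07 log units; within the scatter), and replacing 4-methoxyphenyl gives a 1.3-fold higher number from compound 1 to compound 4 (0.10 log units; within the scatter). Size at this place therefore shows no readable effect across compounds 1, 2 and 4. The value of compound 3 is a limit, and the step to compound 4 cannot be read: the limit of > 58000 nM in this assay, at which 1 of the 4 values shown sits.

As far as these compounds go, whether an amine or a carboxylic acid at this place would give a step beyond the scatter remains open.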